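A Halogen Swap on the Shared Core

The compounds below may be only part of what the source reports. "The series", "measured", "known", "first", "only" and "open" are said of these compounds alone.

Measured in a functional assay on the whole organism for inhibition, with Rattus norvegicus as the target; on this read-out higher numbers stand for an effect only at larger amounts of compound and lower numbers for an effect already at smaller amounts:
Compound 1 `O=C1N(CCN2CCC(c3cn(-c4ccc(F)cc4)c4ccc(Cl)cc34)CC2)CCN1c1ccccc1`: > 0.15 umol/kg (a limit, not a number)
Compound 2 `Fc1ccc(-n2cc(C3=CCNCC3)c3cc(Cl)ccc32)cc1`: 1.5 umol/kg
Compound 3 `CN1CC=C(c2cn(-c3ccc(F)cc3)c3ccc(Cl)cc23)CC1`: 0.058 umol/kg

Compound 3 has the lower of the two exact numbers in this assay, and its nearest neighbour is compound 2. Compound 4 `CN1CC=C(c2cn(-c3ccc(F)cc3)c3ccc(F)cc23)CC1` carries fluoro in place of chloro on an aromatic carbon. Within the data shown here, the only measured step, a 26-fold lower number from compound 2 to compound 3 (1.41 log units; beyond the scatter), is methyl in place of hydrogen on an amine nitrogen in a ring. Among the measured compounds shown here, it is large, but it concerns a different change, and no measured step exchanges one halogen for another. No shift beyond the scatter is therefore expected in this assay. The expected change is small, a 1.4-fold higher number from compound 3 to compound 4 (0.14 log units; within the scatter). For compound 4 the estimate is 0.08 umol/kg, with an expected range from 0.025 umol/kg to 0.3 umol/kg.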

Compound 4, dose for half-maximal effect: 0.15 umol/kg
Beside the measured number, compound 4's estimate is 1.9-fold (0.27 log units) below it; the measured number falls inside the stated range.
By their numbers in this assay, from the lowest: compound 3; then compound 4; then compound 2.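

In this assay the swap gives a 2.6-fold higher number from compound 3 to compound 4 (0.41 log units; beyond the scatter) and so shows that this aromatic carbon of the shared core is not indifferent to which halogen it carries. The earlier compounds had shown a step only at the amine nitrogen in a ring, and this modest step is the first read at a halogen. Nothing shown accounts for the step. On these data alone, whether bromo, methyl or plain hydrogen at this place would move the number further stays open, as does whether the same swap would give a similar step with hydrogen on the ring nitrogen.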